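The source may report more compounds than this note shows. Statements on the series, on what has been measured and on what is new or still open speak of the compounds shown alone.

Compound 2 `CC(C)OC(=O)C1=CN(C(=O)C2CCCCC2)CC(C)(C)c2cc(C#N)[nH]c21` gives 6.5 nM in an assay on HEK293 cells for agonist activity at Bile acid receptor (Homo sapiens), read by a luciferase reporter (on this read-out lower numbers stand for an effect already at smaller amounts and higher numbers for an effect only at larger amounts of compound), the higher of the two numbers recorded, while its nearest neighbour compound 1 `CC(C)OC(=O)C1=CN(C(=O)c2ccc(F)cc2)CC(C)(C)c2cc(C#N)[nH]c21` gives 5 nM. The step of a 1.3-fold higher number from compound 1 to compound 2 (0.11 log units; within the scatter) therefore lay within the scatter. Compound 3 `CC(C)OC(=O)C1=CN(C(=O)c2cccc(C(F)(F)F)c2)CC(C)(C)c2cc(C#N)[nH]c21` carries 3-(trifluoromethyl)phenyl in place of cyclohexyl on a carbonyl carbon. Among the measured compounds shown here, only that single step, exchanging an aromatic ring for cyclohexyl at the same carbonyl carbon, bears on the new change, and since it showed no effect beyond the scatter, none beyond the scatter is expected in this assay from compound 2 to compound 3 either. Compound 3 is thus estimated at 6 nM, ranging from 2 nM to 18 nM. That corresponds to an expected step of a 1.1-fold lower number from compound 2 to compound 3 (0.03 log units; within the scatter).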

Compound 3, half-maximal effective concentration: 8.5 nM
Estimate against measurement, compound 3: 1.4-fold (0.15 log units) below; measured number inside the range.
By their numbers in this assay, from the lowest: compounds 1, 2 and 3 (each within the scatter of the next).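

In this assay, the exchange on the carbonyl carbon gives a 1.3-fold higher number from compound 2 to compound 3 (0.12 log units; within the scatter), and the comparison with the other aromatic group gives a 1.7-fold higher number from compound 1 to compound 3 (0.23 log units; within the scatter). Both steps lie within the scatter, so 3-(trifluoromethyl)phenyl, cyclohexyl and 4-fluorophenyl cannot be told apart at this position, and the tolerance seen earlier now extends to a trifluoromethyl-bearing ring. Nothing available explains this sameness.

As far as these compounds go, all three groups are carbon rings without hydrogen-bond donors or acceptors, so it remains open whether a carboxylic acid, an amine or a longer alkyl chain at this carbonyl carbon would shift the number beyond the scatter.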